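Compound 3: a small step expected from compound 2

The compounds below may be only part of what the source reports. "The series", "measured", "known", "first", "only" and "open" are said of these compounds alone.

Measured so far in a physicochemical assay for lipophilicity, measured as octanol-water partition; on this read-out lower numbers stand for lower lipophilicity and higher numbers for higher lipophilicity:
- Compound 1 `O=C(NNc1ccnc2cc(Cl)ccc12)c1ccccc1/N=C/c1ccc(F)cc1` gives 5.18
- Compound 2 `CN(C)c1ccc(/C=N/c2ccccc2C(=O)NNc2ccnc3cc(Cl)ccc23)cc1` gives 5.03

Going by the values given here, on these two numbers, compound 2 has no clear place of its own, as the only measured step is a number 0.15 log units lower from compound 1 to compound 2 (within the scatter). Compound 3 `O=C(NNc1ccnc2cc(Cl)ccc12)c1ccccc1/N=C/C=C/c1ccccc1` has not yet been measured. It differs from compound 2 as follows: 2-phenylethenyl in place of 4-(dimethylamino)phenyl on a carbon with a double bond to nitrogen. In words, this is 2-phenylethenyl in place of 4-(dimethylamino)phenyl on a carbon with a double bond to nitrogen.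

The measured step bears on this change only loosely. Among the compounds with values here, it exchanges fluoro for dimethylamino on an aromatic carbon, whereas here the whole 4-(dimethylamino)phenyl leaves, and no measured compound carries 2-phenylethenyl. Within the data shown here, still, no change beyond the scatter is expected in this assay because a number 0.15 log units lower from compound 1 to compound 2 (within the scatter) is the only evidence available. The expected step is a number 0.17 log units higher from compound 2 to compound 3 (within the scatter). Compound 3 is estimated at 5.2, with an expected range of 4.8 to 5.6.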

Compound 3, partition coefficient: 5.54
Compound 3: middle estimate off by 0.34 log units, on the low side, within the range that was stated.
By their numbers in this assay, from the lowest: compounds 2 and 1 (each within the scatter of the next); then compound 3.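

In this assay the carbon with a double bond to nitrogen now shows a clear response to the group it carries: 2-phenylethenyl in place of 4-(dimethylamino)phenyl gives a number 0.51 log units higher from compound 2 to compound 3 (beyond the scatter) and so clears the scatter, which the earlier exchange of fluoro for dimethylamino did not. The same entering group in place of 4-fluorophenyl gives a number 0.36 log units higher from compound 1 to compound 3 (beyond the scatter) in the same direction, so compound 3 stands apart from both earlier compounds, which remain within the scatter of each other. No measurement given here accounts for this rise.

Both steps exchange a whole substituted phenyl group for 2-phenylethenyl, so the compounds shown do not separate the entering double bond outside aromatic rings from the loss of the fluoro or dimethylamino group. Going by these compounds, whether the higher number would hold with a saturated 2-phenylethyl group on this carbon, or with an amine or a carboxylic acid on the phenyl of the 2-phenylethenyl group, remains open.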